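The source may report more compounds than this note shows. Statements on the series, on what has been measured and on what is new or still open speak of the compounds shown alone.

Measured compounds:
- compound 1 `Cc1cccc(-c2noc(C3CN(C(=O)C4CCC(C(F)(F)F)CC4)C3)n2)c1`: > 10000 nM
- compound 2 `O=C(c1ccc(F)cc1)N1CC(c2nc(-c3cccc(F)c3)no2)C1`: > 10000 nM
- compound 3 `O=C(c1ccc(F)cc1)N1CC(c2nc(-c3cccc(Cl)c3)no2)C1`: 4000 nM

In an assay on HEK293 cells for negative allosteric modulation of metabotropic glutamate receptor 5 (Homo sapiens), read by FLIPR (on this read-out lower numbers stand for stronger inhibition and higher numbers for weaker inhibition), compound 2 gives > 10000 nM, which is a limit of the assay and not a number. Compound 1 likewise sits at a limit in this assay with > 10000 nM. Among the measured compounds shown here, compound 3 gives 4000 nM in this assay, the only numeric value so far; the step of an at least 2.5-fold lower number from compound 2 to compound 3 (0.39 log units; beyond the scatter) is beyond the scatter, but it concerns the aryl side of the shared core and not the carbonyl side. The evidence is thin: the limit of > 10000 nM in this assay, at which 2 of the 3 values shown sit.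

Compound 4 `CC1CCCCC1C(=O)N1CC(c2nc(-c3cccc(F)c3)no2)C1` is not yet measured. It differs from compound 2 by 2-methylcyclohexyl in place of 4-fluorophenyl on a carbonyl carbon. For the measured compounds named here, no measured step changes the group on the carbonyl carbon, so nothing directly bears on this change. Compound 1 carries a non-aromatic ring at that carbonyl carbon and also stays at the limit, though it differs from compound 2 in two places. The expected step is a step that the limit leaves unreadable from compound 2 to compound 4, that is, no change beyond the scatter, with compound 4 most likely remaining at the limit of this assay. Compound 4 is estimated at 15000 nM, within 4000 nM to 60000 nM.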

Compound 4, half-maximal inhibitory concentration: > 10000 nM
Compound 4 ended at the assay's limit; the forecaster's own chance of this, stated with the estimate: 70%; the middle value lies beyond the limit too.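

Compound 2 and compound 4 yield no readable step in this assay, as both stand at a limit of the assay and not at a number: the limit of > 10000 nM in this assay, at which 3 of the 4 values shown sit.

The compounds shown leave open whether 2-methylcyclohexyl in place of 4-fluorophenyl on a carbonyl carbon changes inhibition at all.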